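This account rests on a few compounds, and the source may have more. Where it says the series, first, only, none or still open, it means among the compounds named here.

Compound 1 `O=C1C=CC(=O)N1c1cc(C(F)(F)F)cc(C(F)(F)F)c1` and compound 2 `C=Cc1cc(C(F)(F)F)cc(C(F)(F)F)c1` have been run in an ADME assay for pharmacokinetics, read by LC-MS, in phosphate buffer, with a stated time of 72 h, at pH 7.4, tested at 250 uM; a lower number here means that the compound disappears faster, a higher number that the compound lasts longer. In this assay compound 1 gives < 0.017 h, which is a limit of the assay (the limit of < 0.017 h in this assay, at which 1 of the 2 values shown sits). Compound 2 gives > 50 h, likewise only a limit (the limit of > 50 h in this assay, at which 1 of the 2 values shown sits). Among the compounds with values here, the sole measured step, an at least 2900-fold higher number from compound 1 to compound 2 (3.46 log units; beyond the scatter), is large and concerns the same aromatic carbon, so it sets a scale rather than a direction for the next change. Compound 3 `FC(F)(F)c1cc(C2CO2)cc(C(F)(F)F)c1` differs from compound 2 by oxiran-2-yl in place of vinyl on an aromatic carbon. For compound 3 a moderate decrease in half-life is expected, an at least 1.6-fold lower number from compound 2 to compound 3 (0.22 log units; that floor lies within the scatter), well short of the measured step. The estimate for compound 3 is 30 h, ranging from 8 h to 120 h.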

Compound 3, half-life: > 50 h
Compound 3: a limit, no number (the forecaster's own chance of this, stated with the estimate: 35%); middle value at least 1.6-fold (0.22 log units) from the limit.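

In this assay compound 3 gives > 50 h as a limit of the assay, not a number. The step between compound 2 and compound 3 cannot be read, as both sit at the same limit: the limit of > 50 h in this assay, at which 2 of the 3 values shown sit. Within the data shown here, with oxiran-2-yl on this aromatic carbon the series also shows an at least 2900-fold higher number from compound 1 to compound 3 (3.46 log units; beyond the scatter), so vinyl is no longer the only group with a large step from the five-membered ring group. From the compounds shown here alone, whether oxiran-2-yl and vinyl differ stays open. So does the half-life with an amine, a carboxylic acid or a longer chain on this carbon.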